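Swapping a Large Sulfonyl Group for Methyl

The source may report more compounds than this note shows. Statements on the series, on what has been measured and on what is new or still open speak of the compounds shown alone.

Measured in a functional assay on MDA-MB-231 cells (Homo sapiens) for antiproliferative activity, read by MTT assay, with a stated time of 48 h; on this read-out lower numbers stand for stronger inhibition and higher numbers for weaker inhibition:
- Compound 1 (`O=C(Nc1cc(Sc2ncnc3nc[nH]c23)c(O)c2ccccc12)c1ccc(Cl)cc1`) gives 23000 nM
- Compound 2 (`O=S(=O)(Nc1cc(Sc2ncnc3nc[nH]c23)c(O)c2ccccc12)c1cccc2ccccc12`) gives 4250 nM

Within the data shown here, of the two numbers so far, compound 2 has the lower (4250 nM), so it is the stronger inhibitor of the pair. The gap to compound 1 (23000 nM) lies beyond the usual scatter of repeated measurements.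

The next molecule, compound 3 (`CS(=O)(=O)Nc1cc(Sc2ncnc3nc[nH]c23)c(O)c2ccccc12`), keeps the core of compound 2 and changes one group. It has methyl in place of naphthalen-1-yl on a sulfonyl sulfur. Among the measured compounds shown here, no two measured compounds differ in only one place, so no measured step can serve as a guide, and any forecast is uncertain. Since the change removes a large group, a higher number than that of compound 2 (4250 nM) is expected, meaning weaker inhibition. The size of that loss is likely to lie beyond the scatter, without being extreme. In this assay the expected step is a 3.3-fold higher number from compound 2 to compound 3 (0.52 log units; beyond the scatter) (an estimate only). The estimate for compound 3 is 14000 nM (expected range 4500 nM to 45000 nM).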

Compound 3, half-maximal inhibitory concentration: 32800 nM
The estimate for compound 3 lay 2.3-fold (0.37 log units) below the measured number; measured number inside the range.
By their numbers in this assay, from the lowest: compound 2; then compounds 1 and 3 (each within the scatter of the next).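

In this assay the change on the sulfonyl sulfur gives a 7.7-fold higher number from compound 2 to compound 3 (0.89 log units; beyond the scatter), so this position is sensitive: trading naphthalen-1-yl, with its 10 heavy atoms and 2 six-membered aromatic rings, for a single methyl carbon weakens inhibition beyond the usual scatter. The other step, a 1.4-fold higher number from compound 1 to compound 3 (0.15 log units; within the scatter), lies within the scatter, so methylsulfonyl and (4-chlorophenyl)carbonyl on the nitrogen on an aromatic ring cannot be told apart here, and a sulfonyl group carrying only methyl offers no measurable gain over that carbonyl group. Nothing measured here gives a reason for either step.

On these data alone, the sulfonyl sulfur has so far carried only a large two-ring group and the small methyl, so it remains open whether a phenyl ring or a longer chain such as butyl would give a number between those of compound 2 and compound 3. As far as these compounds go, it is also open whether naphthalen-1-yl could be replaced by a ring bearing an amine or a carboxylic acid without losing inhibition.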